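Changing the aryl group on the piperazine of compound 3

The compounds below may be only part of what the source reports. "The series", "measured", "known", "first", "only" and "open" are said of these compounds alone.

In a functional assay on the whole organism (Abdomen, strain Swiss) for inhibition, with Mus musculus as the target, with stated times of 30 min, 10 min and 5 min, at a dose of 20 mg/kg by the oral route (on this read-out higher numbers stand for a stronger effect at the one dose given and lower numbers for a weaker effect), three compounds have been measured. Compound 1 `CCCCC(=O)c1c(C)nn(CCCN2CCN(c3ccc(C)cc3)CC2)c(=O)c1N` gives 23%, compound 2 `C=Cc1c(CC)nn(CCCN2CCN(c3ccc(C)cc3)CC2)c(=O)c1N` gives 0%, and compound 3 `Cc1c(C#N)c(-c2ccccc2)nn1CCCN1CCN(c2ccc(F)cc2)CC1` gives 28%. The number for compound 3 is the highest of the three, yet that of compound 1 lies within the scatter of it, while compound 2 sits beyond the scatter below it. Compound 4 `COc1cccc(N2CCN(CCCn3nc(-c4ccccc4)c(C#N)c3C)CC2)c1` differs from compound 3 in one place: 3-methoxyphenyl in place of 4-fluorophenyl on an amine nitrogen in a ring. Within the data shown here, no measured pair shows this kind of change, so there is nothing to tell its size. In this assay compound 4 is therefore expected near compound 3, with a step of a number 3 percentage points lower from compound 3 to compound 4 (within the scatter) that does not go beyond the scatter in either direction. The estimate for compound 4 is 25%, within a range from 5% to 45%.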

Compound 4, a percentage reported as inhibition, in the whole organism at one dose (the size of the read-out at that dose, not a potency): 21%
For compound 4 the middle estimate is 4 percentage points above the measured one; low and high end bracket the measured number.
By their numbers in this assay, from the lowest: compound 2; then compounds 4, 1 and 3 (each within the scatter of the next).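

In this assay, 3-methoxyphenyl in place of 4-fluorophenyl on an amine nitrogen in a ring gives a number 7 percentage points lower from compound 3 to compound 4 (within the scatter). This first reading of a change at this position shows that the position takes 3-methoxyphenyl, with its hydrogen-bond acceptor, without a step beyond the scatter. Nothing available bears on the cause of this step. Still open, on these data alone, is how an unsubstituted phenyl or a benzyl group would read on that nitrogen. Also open, as far as these compounds go, is whether the same change would give a similar step on the core of compound 1.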